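Removing one methoxy group from the trimethoxyphenyl-bearing chalcone

This account rests on a few compounds, and the source may have more. Where it says the series, first, only, none or still open, it means among the compounds named here.

Measured compounds:
compound 1, `COc1cc(-c2cc(/C=C/C(=O)c3ccc(N)cc3)[nH]n2)cc(OC)c1OC`: 90%
compound 2, `COc1ccc(C(=O)/C=C/c2cc(-c3cc(OC)c(OC)c(OC)c3)n[nH]2)cc1OC`: 96%
compound 3, `COc1ccc(C(=O)/C=C/c2cc(-c3cc(OC)c(OC)c(OC)c3)n[nH]2)cc1`: 101%

All three compounds were examined in a functional assay on SK-MEL-28 cells (Homo sapiens) for cytotoxicity, read by sulforhodamine B assay, with a stated time of 48 h, tested at 1 uM; on this read-out lower numbers stand for a stronger effect and higher numbers for a weaker effect at the one concentration tested. The numbers lie close together: the step of a number 6 percentage points higher from compound 1 to compound 2 (within the scatter) is within the scatter, as is a number 5 percentage points higher from compound 2 to compound 3 (within the scatter), while only a number 11 percentage points higher from compound 1 to compound 3 (beyond the scatter) reaches beyond it, and even that is modest. The cores of compound 1 and compound 2 differ at the carbonyl carbon, where 4-aminophenyl in place of 3,4-dimethoxyphenyl on a carbonyl carbon sets them apart.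

Compound 4, `COc1ccc(-c2cc(/C=C/C(=O)c3ccc(N)cc3)[nH]n2)cc1OC`, has not yet been measured. It arises from compound 1 through (hydrogen in place of methoxy on an aromatic carbon). The same kind of change links compound 2 to compound 3, where hydrogen in place of methoxy on an aromatic carbon applies; the surroundings differ only in that the place in compound 1 is also meta to a methoxy group, which is not the case in compound 2. That earlier step, a number 5 percentage points higher from compound 2 to compound 3 (within the scatter), stayed within the scatter.

Resting on that single observed step, compound 4 is expected to stay close to compound 1, because a number 5 percentage points higher from compound 2 to compound 3 (within the scatter) gave no meaningful shift; the expected step is a number 4 percentage points higher from compound 1 to compound 4 (within the scatter). The estimate for compound 4 is therefore 94%, with a range expected from 84% to 104%.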

Compound 4, a percentage reported as activity, at one concentration (the size of the read-out at that concentration, not a potency): 89%
Beside the measured number, compound 4's estimate is 5 percentage points above it; measured number inside the range.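

In this assay, hydrogen in place of methoxy on an aromatic carbon of the core of compound 1 gave a number 1 percentage points lower from compound 1 to compound 4 (within the scatter), so removing this methoxy group again produced no meaningful shift. Set beside the earlier case, the two steps do not differ, and on these two cores the change carries over as a step that stays inside the usual scatter: the same change on two cores in this assay, a number 5 percentage points higher (within the scatter) from compound 2 to compound 3 and a number 1 percentage points lower (within the scatter) from compound 1 to compound 4, 6 percentage points apart, within the scatter of two such steps. This shows only that the absence of a clear shift held on both cores at the one concentration tested; neither step is a real shift that could be carried across, so the pair does not test whether a genuine effect of this change would transfer, and it gives no potency and says nothing about cores beyond these two.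

The compounds shown leave open what a different group at this place would do, such as a hydroxyl, a fluorine or a longer chain like ethoxy, since methoxy and hydrogen are the only two seen there. They also leave open whether replacing the amino group on the core of compound 4 with another group, such as a carboxylic acid or an amide, would change the read-out.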